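Adding a vinyl group to compound 3

The compounds below may be only part of what the source reports. "The series", "measured", "known", "first", "only" and "open" are said of these compounds alone.

In a functional assay on the whole organism with Rattus norvegicus as the target (a lower number here means that less compound is needed, a higher number that more compound is needed for the effect), compound 1 `CC(C)(C)Cc1ccc2nc(N)sc2c1` gives > 10 mg/kg, which is a limit of the assay and not a number. Compound 2 `Nc1nc2ccc(C(=O)C(F)(F)F)cc2s1` gives > 10 mg/kg, which is also only a limit. Among the measured compounds shown here, compound 3 `Cn1c(=N)sc2cc(OC(F)(F)F)ccc21` gives 5 mg/kg, the only actual number so far, so it has no measured number to be compared with.

Compound 4 `C=CCn1c(=N)sc2cc(OC(F)(F)F)ccc21` keeps the core of compound 3 and differs in one place: vinyl in place of hydrogen on a saturated chain carbon bound to an aromatic nitrogen. Seen one bond further out, this change reads methyl to allyl.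

For the measured compounds named here, no measured pair of compounds shows what such a change does, so the expectation here is a cautious one. The estimated step of a 1.2-fold higher number from compound 3 to compound 4 (0.08 log units; within the scatter) is expected to stay within the usual scatter of this assay, with no clear direction. The expected value for compound 4 is 6 mg/kg, with an estimated range from 2 mg/kg to 15 mg/kg.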

Compound 4, dose for half-maximal effect: 7 mg/kg
Compound 4: middle estimate off by 1.2-fold (0.07 log units), on the low side; low and high end bracket the measured number.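

In this assay, among the compounds shown here, the first step that can be read in this set is a 1.4-fold higher number from compound 3 to compound 4 (0.15 log units; within the scatter), and it comes from changing methyl to allyl at a saturated chain carbon bound to an aromatic nitrogen. This place therefore accepts the added vinyl group without a change that can be told apart from the scatter. Compound 4 also joins compound 3 in giving an actual number, which matters in a set where limits of the assay are common: the limit of > 10 mg/kg in this assay, at which 2 of the 4 values shown sit.

Going by these compounds, it remains open whether the double bond itself matters, which a plain propyl group at this place could help to show. On these data alone, it is also open whether a longer chain, or a chain ending in an amine or a carboxylic acid, would move the number beyond the scatter.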